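A few compounds are considered here, and "the series" means these few. Any claim that something is new, unique, unknown or untested is made for them only; others in the source may bear on it.

Among the compounds with values here, compound 2 `COc1ccc(/C=N/NC(=S)N/N=C2\C(=O)Nc3ccc(Br)cc32)cc1O` is the only compound here with a number in a functional assay on COS-7 cells (Chlorocebus aethiops) for inhibition, read by MTT assay (on this read-out higher numbers stand for weaker inhibition and lower numbers for stronger inhibition), where compound 2 gives 3090 nM. Compound 1 `O=C1Nc2ccc(Br)cc2/C1=N/NC(=S)N/N=C/c1ccccc1Br` reaches only the limit of this assay, > 50000 nM, which is a limit and not a number (the limit of > 50000 nM in this assay, at which 1 of the 2 values shown sits). Within the data shown here, the single measured step, an at least 16-fold lower number from compound 1 to compound 2 (1.20 log units; beyond the scatter), is large. Compound 3 `O=C1Nc2ccc(Br)cc2/C1=N/NC(=S)N/N=C/c1ccc(Br)cc1` carries 4-bromophenyl in place of 3-hydroxy-4-methoxyphenyl on a carbon with a double bond to nitrogen; this removes the group that arrived with that step, while bromine returns as 4-bromophenyl rather than 2-bromophenyl. A step back toward weaker inhibition is expected, about a 6.5-fold higher number from compound 2 to compound 3 (0.81 log units; beyond the scatter). Compound 3 is estimated at 20000 nM, between 5000 nM and 60000 nM.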

Compound 3, half-maximal inhibitory concentration: 5180 nM
Compound 3: middle estimate off by 3.9-fold (0.59 log units), on the high side; the range from low to high includes it.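

In this assay, 4-bromophenyl in place of 2-bromophenyl gives an at least 9.6-fold lower number from compound 1 to compound 3 (0.98 log units; beyond the scatter), so where the bromine sits on the phenyl ring matters at this carbon with a double bond to nitrogen. Going from 3-hydroxy-4-methoxyphenyl to 4-bromophenyl gives a 1.7-fold higher number from compound 2 to compound 3 (0.22 log units; within the scatter), so the hydroxy and methoxy groups are not required for this level of inhibition. The first of these comparisons gives only a bound, as compound 1 stands at a limit and not at a number: the limit of > 50000 nM in this assay, at which 1 of the 3 values shown sits.

Going by these compounds, whether a plain phenyl, or a phenyl carrying an amine or a carboxylic acid, would match compound 3 at this place stays open.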